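The source may hold more compounds than are shown below. What is called first, only, known or untested is meant among the compounds shown, and "the series" means these compounds.

Compound 1 `CC1CCN(C2CCN(S(=O)(=O)c3cccc(N)c3)CC2)CC1` and compound 2 `CC1CCN(C2CCN(S(=O)(=O)c3cccc(-c4ccccc4)c3)CC2)CC1` share a core and differ only in the group on the aromatic ring attached to the sulfonyl sulfur. In a functional assay on DLD-1 cells (Homo sapiens) for antiproliferative activity, read by CellTiter-Glo, with a stated time of 72 h (on this read-out higher numbers stand for weaker inhibition and lower numbers for stronger inhibition), compound 1 gives 3400 nM, the highest of the two numbers available, while compound 2 gives 2 nM. Going by the values given here, the only step so far, a 1700-fold lower number from compound 1 to compound 2 (3.23 log units; beyond the scatter), shows how much a single change on that ring can move the read-out.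

Compound 3 `CC1CCN(C2CCN(S(=O)(=O)c3ccc(Cl)cc3Cl)CC2)CC1` is not yet measured. It differs from compound 1 by 2,4-dichlorophenyl in place of 3-aminophenyl on a sulfonyl sulfur. Among the compounds with values here, the step from compound 1 to compound 2 bears on this change only in part: both replace the amino group, but with different entering groups, and no measured pair shows a 2,4-dichlorophenyl directly. Within the data shown here, a move toward lower numbers in this assay is therefore expected, yet with far less certainty about its size than the one step alone would suggest. Compound 3 is expected to give 100 nM, within a range of 10 nM to 1000 nM. That estimate amounts to an expected step of a 34-fold lower number from compound 1 to compound 3 (1.53 log units; beyond the scatter).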

Compound 3, half-maximal inhibitory concentration: 1 nM
Beside the measured number, compound 3's estimate is 100-fold (2.00 log units) above it; the measured number lies below the stated range.
By their numbers in this assay, from the lowest: compounds 3 and 2 (each within the scatter of the next); then compound 1.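

Replacing 3-aminophenyl with 2,4-dichlorophenyl on a sulfonyl sulfur gives a 3400-fold lower number from compound 1 to compound 3 (3.53 log units; beyond the scatter) in this assay, so a large step at this position is no longer tied to the phenyl group that entered in compound 2. Compound 2 at 2 nM and compound 3 at 1 nM lie within the scatter of each other, which shows that two different aromatic groups on the shared core can both reach numbers this low. No measurement offered here accounts for the size of the step or for the agreement between these two compounds.

The compounds shown leave open how an unsubstituted phenyl, a single chlorine or a methoxy group on this ring would read in this assay, and so whether both chlorine atoms matter or whether the high number of compound 1 simply goes with its amino group. They also leave open whether numbers this low would hold with a carboxylic acid or a longer chain in place of the methyl group on the shared core.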